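The source may report more compounds than this note shows. Statements on the series, on what has been measured and on what is new or still open speak of the compounds shown alone.

Measured in an assay on brain for displacement of a labelled ligand from D(3) dopamine receptor (Rattus norvegicus); on this read-out lower numbers stand for stronger inhibition and higher numbers for weaker inhibition:
compound 1, `CCCN(CC[C@H]1CC[C@H](NC(=O)/C=C/c2ccc(OC)cc2)CC1)[C@H]1CCc2nc(N)sc2C1`, gives 6.7 nM
compound 2, `CCCN(CC[C@H]1CC[C@H](NC(=O)c2cccc(-c3noc(CC)n3)c2)CC1)[C@H]1CCc2nc(N)sc2C1`, gives 1.5 nM
compound 3, `CCCN(CC[C@H]1CC[C@H](NS(=O)(=O)c2ccc(-c3ccccc3)cc2)CC1)[C@H]1CCc2nc(N)sc2C1`, gives 41 nM

Compound 3 stands highest of the three numbers. Compound 1 sits nearest to it, with a number lower by a margin beyond the usual scatter, and compound 2 is furthest away, lower still. Going by the values given here, compounds 1 and 2 carry amides where compound 3 carries a sulfonamide, and no pair among the three differs in a single place, so nothing in hand isolates what the sulfonamide or the 4-phenylphenyl group of compound 3 contributes on its own.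

Compound 4, `CCCN(CC[C@H]1CC[C@H](NS(=O)(=O)c2ccc(C(C)C)cc2)CC1)[C@H]1CCc2nc(N)sc2C1`, is the next step from compound 3 in this assay. The change is isopropyl in place of phenyl on an aromatic carbon, so the 4-phenylphenyl sulfonamide of compound 3 becomes a 4-isopropylphenyl sulfonamide. Among the compounds with values here, no measured pair in the set shows a step of this kind, and the three numbers give no direction for it. The expectation is a small step, likely none beyond the scatter, with a slight lean toward a higher number in this assay, namely a 1.2-fold higher number from compound 3 to compound 4 (0.09 log units; within the scatter). Compound 4 is therefore estimated at 50 nM, with a range from 15 nM to 160 nM.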

Compound 4, inhibition constant: 4.5 nM
Compound 4: the middle estimate sits 11-fold (1.05 log units) above what was measured; the measured number lies below the stated range.
By their numbers in this assay, from the lowest: compound 2; then compounds 4 and 1 (each within the scatter of the next); then compound 3.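

In this assay the series gains its first single-place comparison, and a 9.1-fold lower number from compound 3 to compound 4 (0.96 log units; beyond the scatter) is a step beyond the scatter. With the sulfonamide and the rest of the structure unchanged, the number at this position, on an aromatic carbon para to a large group, depends on what the position carries, and isopropyl goes with the lower number when set against phenyl. Going by these compounds alone, the second aromatic ring of the 4-phenylphenyl group is therefore not required for the value of compound 4 (4.5 nM), and nothing measured so far gives a reason for the step.

As far as these compounds go, with only phenyl and isopropyl compared here, it remains open whether a methyl, a tert-butyl, a methoxy group or a chlorine atom at the same position would follow isopropyl or phenyl, and so whether the step tracks ring removal or the particular alkyl group. Also open is whether the same exchange would move the number in the same direction on an amide in place of the sulfonamide, since no amide shown here carries either of these two groups.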